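From 1-aminocyclopentyl to 1-hydroxyethyl on a carbonyl carbon

The source may hold more compounds than are shown below. What is called first, only, known or untested is meant among the compounds shown, and "the series" means these compounds.

The read-out here is an in vitro ADME assay on microsomes (Mus musculus) for metabolic stability; a lower number here means that the compound disappears faster, a higher number that the compound lasts longer. Compound 1 `CC(=O)N1CCc2c(C)c3c(n2-c2ccc(C(N)=O)c(c2)N[C@@H](C)[C@H](C)C1)CC(C)(C)CC3=O` gives 0.0667 h, and compound 3 `Cc1c2c(n3c1CCN(C(=O)C1(N)CCCC1)C[C@@H](C)[C@H](C)Nc1cc-3ccc1C(N)=O)CC(C)(C)CC2=O` gives 0.0833 h. These two values stand together, the step being a 1.2-fold higher number from compound 1 to compound 3 (0.10 log units; within the scatter). Compound 2 `Cc1c2c(n3c1CCN(C(=O)CN)C[C@@H](C)[C@H](C)Nc1cc-3ccc1C(N)=O)CC(C)(C)CC2=O` gives > 0.5 h, which is a limit of the assay and not a number. Compound 3 therefore sits with compound 1, and the step to it from the limit is an at least 6.0-fold lower number from compound 2 to compound 3 (0.77 log units; beyond the scatter).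

Compound 4 `Cc1c2c(n3c1CCN(C(=O)[C@H](C)O)C[C@@H](C)[C@H](C)Nc1cc-3ccc1C(N)=O)CC(C)(C)CC2=O` differs from compound 3 as follows: 1-hydroxyethyl in place of 1-aminocyclopentyl on a carbonyl carbon. In words, this is 1-hydroxyethyl in place of 1-aminocyclopentyl on a carbonyl carbon.

Going by the values given here, two steps bear most directly on the change. Adding amino to the chain gave an at least 7.4-fold higher number from compound 1 to compound 2 (0.87 log units; beyond the scatter), and 1-aminocyclopentyl in place of aminomethyl gave an at least 6.0-fold lower number from compound 2 to compound 3 (0.77 log units; beyond the scatter). Like the aminomethyl of compound 2, the entering group has no ring, which points upward. Compound 1 goes against a simple reading, since its methyl also has no ring and it gives 0.0667 h. Among the compounds with values here, no measured compound carries the hydroxy group, so only part of the rise is expected. The expected change is a 2.4-fold higher number from compound 3 to compound 4 (0.38 log units; beyond the scatter). For compound 4 the estimated half-life is 0.2 h, with an expected range of 0.07 h to 0.5 h.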

Compound 4, half-life: > 0.5 h
Compound 4: a limit, no number; the forecaster's own chance of this, stated with the estimate: 20%; middle value at least 2.5-fold (0.39 log units) away from the limit.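

In this assay, the rise at this position no longer depends on an amino group: on the carbonyl carbon, 1-hydroxyethyl gives an at least 6.0-fold higher number from compound 3 to compound 4 (0.77 log units; beyond the scatter) and an at least 7.4-fold higher number from compound 1 to compound 4 (0.87 log units; beyond the scatter). Going by these compounds alone, the entering group carries oxygen, and the only earlier group to reach the limit, the aminomethyl of compound 2, carries nitrogen, so more than one kind of group on this carbon can bring a compound there. Among the compounds shown, the two with a heteroatom-bearing group and no ring reach the limit, while compound 1, with a methyl and no ring, and compound 3, with an amino group on a cyclopentyl ring, go against any reading based on the absence of a ring or the presence of an amino group alone.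

Compound 2 and compound 4 both stand at a limit and not at a number, so the step between them cannot be read and their order stays unknown: the limit of > 0.5 h in this assay, at which 2 of the 4 values shown sit.
From the compounds shown here alone, it also remains open whether the hydroxy group itself carries the rise, as a methoxy group, a longer chain such as 2-hydroxyethyl, or the opposite stereocentre of 1-hydroxyethyl on the same carbonyl carbon would test.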